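A few compounds are considered here, and "the series" means these few. Any claim that something is new, unique, unknown or untested is made for them only; others in the source may bear on it.

Compound 1 `CC1(C)O[C@H]2[C@H](OCc3noc(-c4ccc([N+](=O)[O-])cc4)n3)O[C@H](CSc3ncn[nH]3)[C@H]2O1` is a sugar-based molecule carrying a nitrophenyl-oxadiazole unit and a triazole-sulfur arm. In a functional assay on HBL-100 cells (Homo sapiens) for antiproliferative activity, read by sulforhodamine B assay, with a stated time of 48 h (a lower number here means a stronger inhibitor of growth, a higher number a weaker inhibitor of growth), compound 1 gives only a limit of > 100000 nM, so no number is known for it. Compound 2 `O=[N+]([O-])c1ccc(-c2nc(CO[C@@H]3O[C@H](CSc4ncn[nH]4)[C@H]4OC5(CCCC5)O[C@@H]34)no2)cc1` differs from compound 1 in its ketal portion and not in one single place. In this assay compound 2 gives 24000 nM. Compound 1 is therefore the weaker of the two measured compounds, sitting at the assay limit, a position described by the limit of > 100000 nM in this assay, at which 1 of the 2 values shown sits.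

Compound 3 `CC1(C)O[C@H]2[C@H](OCc3noc(-c4ccc([N+](=O)[O-])cc4)n3)O[C@H](CO)[C@H]2O1` arises from compound 1 by a single change: hydroxy in place of (1H-1,2,4-triazol-5-yl)sulfanyl on a saturated chain carbon bound to a saturated ring carbon. For the measured compounds named here, no measured pair shows what this particular change does in this assay. The expectation for the step from compound 1 to compound 3 is a step that the limit leaves unreadable from compound 1 to compound 3, that is, nothing beyond the scatter. Compound 3 is estimated at 150000 nM, within a range from 50000 nM to 500000 nM, and most likely again only a limit.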

Compound 3, concentration for 50% growth inhibition: 99000 nM
Compound 3: middle estimate off by 1.5-fold (0.18 log units), on the high side; the range from low to high includes it.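

With hydroxy in place of (1H-1,2,4-triazol-5-yl)sulfanyl, the core of compound 1 yields a readable number: in this assay compound 3 gives 99000 nM. For compound 1, the > 100000 nM is a limit and not a number. The change gives a number no higher from compound 1 to compound 3 (the limit leaves the size open), so a compound without the triazole ring still inhibits growth only weakly at this position, and how much the change shifts activity stays unknown: the limit of > 100000 nM in this assay, at which 1 of the 3 values shown sits.

From the compounds shown here alone, whether the (1H-1,2,4-triazol-5-yl)sulfanyl group contributes anything at all remains open, as compound 1 offers no number for comparison. Also open, going by these compounds, are how an amine or a carboxylic acid would behave on this saturated chain carbon, and whether hydroxy would have a similar outcome with the ketal of compound 2.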